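The compounds below may be only part of what the source reports. "The series", "measured", "known", "first", "only" and "open" are said of these compounds alone.

Working notes on the series. Compound 2 `O=c1c2cc(Cl)ccc2ccn1[C@@H]1O[C@H](COP(=O)(O)OP(=O)(O)OP(=O)(O)O)[C@@H](O)[C@H]1O` holds the lowest number of the two measured in a functional assay for agonist activity at P2Y purinoceptor 2 (Homo sapiens), read by FLIPR (a higher number here means that more compound is needed for the effect, a lower number that less compound is needed), where compound 2 gives 10 nM. Compound 1 `O=c1c2ccc(Cl)cc2ccn1[C@@H]1O[C@H](COP(=O)(O)OP(=O)(O)OP(=O)(O)O)[C@@H](O)[C@H]1O` gives in this assay a reading of 541 nM, a gap beyond the scatter. Compound 3 `O=c1c2cc(Cl)c(Cl)cc2ccn1[C@@H]1O[C@H](COP(=O)(O)OP(=O)(O)OP(=O)(O)O)[C@@H](O)[C@H]1O` carries chloro in place of hydrogen on an aromatic carbon. Within the data shown here, no pair differing in one place has been measured, so the size of the step is open; a modest rise in the number is expected, a 3.0-fold higher number from compound 2 to compound 3 (0.48 log units; beyond the scatter). For compound 3 the expected value in this assay is 30 nM, within a range of 8 nM to 120 nM.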

Compound 3, half-maximal effective concentration: 13 nM
Estimate against measurement, compound 3: 2.3-fold (0.36 log units) above, and the stated range covers the measured number.
By their numbers in this assay, from the lowest: compounds 2 and 3 (each within the scatter of the next); then compound 1.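

In this assay, chloro in place of hydrogen ortho to the existing chloro group gives a 1.3-fold higher number from compound 2 to compound 3 (0.11 log units; within the scatter) and so leaves the reading within the scatter, which shows that this position accepts a second chloro. The same kind of change at the other chloro position gives a 42-fold lower number from compound 1 to compound 3 (1.62 log units; beyond the scatter) and is large, so the two positions are not equivalent in this assay. Nothing available bears on the reason for this difference. Going by these compounds, whether a methyl, a methoxy, an amine or a carboxylic acid at the position ortho to the chloro group would also leave the reading within the scatter remains open.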